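Swapping a para substituent on the pendant aryl of compound 2

The source may report more compounds than this note shows. Statements on the series, on what has been measured and on what is new or still open speak of the compounds shown alone.

Compound 2 `CCCC(Oc1cnn(-c2ccc(OC)cc2)c1)c1ccc(C(=O)NCCC(=O)O)cc1` is measured in an assay on isolated protein for displacement of a labelled ligand from Glucagon receptor (Homo sapiens) (a higher number here means a weaker inhibitor, a lower number a stronger inhibitor), where compound 2 gives 1980 nM. Two other compounds accompany it: compound 1 `CCCC(Oc1cnn(-c2ccc(C(F)(F)F)cn2)c1)c1ccc(C(=O)NCCC(=O)O)cc1`, which in this assay gives 1190 nM, and compound 3 `CCCc1c(C(C)C)cc(C(C)C)c(C(C)O)c1-c1ccc(F)cc1`, which gives 356 nM. Compound 2 sits at the upper end of the three numbers together with compound 1, the pair being separated by a 1.7-fold higher number from compound 1 to compound 2 (0.22 log units; within the scatter), while compound 3 lies well below both, a gap beyond the scatter.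

The new compound 4 `CCCC(Oc1cnn(-c2ccc(Cl)cc2)c1)c1ccc(C(=O)NCCC(=O)O)cc1` differs from compound 2 in one place: chloro in place of methoxy on an aromatic carbon. For the measured compounds named here, only one measured step bears on this kind of change, the swap of the group on the aromatic nitrogen between compound 1 and compound 2, and that step was a 1.7-fold higher number from compound 1 to compound 2 (0.22 log units; within the scatter), a shift that stayed within the scatter. Going by the values given here, with no step that moved the number clearly in either direction for a change of this kind, the expectation for compound 4 is a step of about a 1.2-fold lower number from compound 2 to compound 4 (0.07 log units; within the scatter), in effect no movement beyond the scatter. Compound 4 is therefore expected to give roughly 1700 nM in this assay, with a plausible range from 700 nM to 4000 nM.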

Compound 4, inhibition constant: 600 nM
Estimate against measurement, compound 4: 2.8-fold (0.45 log units) above; the measured number lies below the stated range.
By their numbers in this assay, from the lowest: compounds 3, 4, 1 and 2 (each within the scatter of the next, the first and the last beyond it).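

In this assay, 4-chlorophenyl in place of 4-methoxyphenyl gives a 3.3-fold lower number from compound 2 to compound 4 (0.52 log units; beyond the scatter), the only step among these compounds that passes beyond the scatter, so the aromatic carbon para to a large group is a place where a single substituent can move the number measurably. The other new step, a 2.0-fold lower number from compound 1 to compound 4 (0.30 log units; within the scatter), stays within the scatter, as does the step between compound 1 and compound 2, so 5-(trifluoromethyl)pyridin-2-yl cannot be told apart from either 4-chlorophenyl or 4-methoxyphenyl, even though those two differ from each other. Nothing measured here accounts for the difference between chloro and methoxy at this place.

As far as these compounds go, whether the shift belongs to chloro alone, or would also come with fluoro, methyl or a nitrile on the same aromatic carbon, stays open. Also open, from the compounds shown here alone, is whether the same exchange would give a step of similar size on a core carrying a tetrazole in place of the carboxylic acid.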